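The source may report more compounds than this note shows. Statements on the series, on what has been measured and on what is new or still open speak of the compounds shown alone.

Working notes on the stilbene series in an assay on HepG2 cells for activation of nuclear factor erythroid 2-related factor 2 (Homo sapiens), read by a luciferase reporter, with a stated time of 5 h; a lower number here means that less compound is needed, a higher number that more compound is needed for the effect.

Of the compounds shown here, three have numbers so far. Compound 1 `Fc1cccc(/C=C/c2ccccc2)c1` gives 3100 nM in this assay. Compound 2 `COc1ccc(/C=C/c2ccc(F)cc2)cc1` gives 4200 nM in this assay. Compound 3 `COc1cccc(/C=C/c2ccc(F)cc2)c1` gives 6000 nM in this assay, the highest of the three numbers, though its distance to compound 2 and to compound 1 both lie within the usual scatter, so no order among the three can be read from these values.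

The next compound, compound 4 `COc1ccc(/C=C/c2ccc(F)cc2)cc1OC`, differs from compound 3 by one change: methoxy in place of hydrogen on an aromatic carbon. Within the data shown here, no comparable single step has been measured, so the size of the step cannot be read from a precedent. Since compound 2, which carries a single methoxy at the position that receives the new group, gives 4200 nM and sits within the scatter of compound 3, the step from compound 3 to compound 4 is expected to be small, with no clear direction and likely not beyond the scatter, as a 1.2-fold lower number from compound 3 to compound 4 (0.08 log units; within the scatter) indicates. Compound 4 is therefore estimated at 5000 nM in this assay, with a range from 2000 nM to 12000 nM.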

Compound 4, half-maximal effective concentration: 2600 nM
The estimate for compound 4 lay 1.9-fold (0.28 log units) above the measured number, and the stated range covers the measured number.
By their numbers in this assay, from the lowest: compounds 4, 1, 2 and 3 (each within the scatter of the next, the first and the last beyond it).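

In this assay, among these compounds, methoxy in place of hydrogen on an aromatic carbon, ortho to a methoxy group and para to a group of 9 heavy atoms, gives a 2.3-fold lower number from compound 3 to compound 4 (0.36 log units; beyond the scatter) and is the one step beyond the scatter. The same kind of change read from compound 2 gives a 1.6-fold lower number from compound 2 to compound 4 (0.21 log units; within the scatter) and stays within the scatter, so compound 4 stands clearly apart only from compound 3. No available data bear on why this position responds in this way.

The compounds shown leave open whether the lower number depends on methoxy itself or would also appear with a hydroxyl group, an amine or a longer alkoxy chain on the same carbon. They also leave open whether the fluorine of compound 4 contributes to its number.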